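Replacing 1,3-thiazol-2-yl on the nitrogen of compound 2

The source may report more compounds than this note shows. Statements on the series, on what has been measured and on what is new or still open speak of the compounds shown alone.

Of the compounds shown here, two have values so far: compound 1 `CNc1nc(SCc2nc3ccccc3[nH]2)nc(-c2ccccc2)c1C#N` and compound 2 `N#Cc1c(Nc2nccs2)nc(SCc2nc3ccccc3[nH]2)nc1-c1ccccc1`. In a functional assay on GOTO cells (Homo sapiens) for cytotoxicity, read by MTT assay, with a stated time of 3 days (a higher number here means a weaker inhibitor, a lower number a stronger inhibitor), compound 1 gives 3.28 nM and compound 2 gives 5.1 nM. These values lie within the scatter of each other, so compound 2 stands level with compound 1 and no order can be drawn between them.

Next in the series is compound 3 `N#Cc1c(NC(N)=S)nc(SCc2nc3ccccc3[nH]2)nc1-c1ccccc1`, which differs from compound 2 as follows: a group of 3 heavy atoms (1 carbon, 1 nitrogen, 1 sulfur; no ring) in place of a group of 5 heavy atoms (3 carbon, 1 nitrogen, 1 sulfur; one five-membered aromatic ring with 2 hetero atoms), on a nitrogen on an aromatic ring. Going by the values given here, the change falls on a nitrogen on an aromatic ring, the same place that varies in the only measured step, a 1.6-fold higher number from compound 1 to compound 2 (0.19 log units; within the scatter). Among the compounds with values here, that step, from methyl to 1,3-thiazol-2-yl, stayed within the scatter and is the only evidence at this place. Within the data shown here, no measured compound carries the entering group, so the evidence is thin and the range must stay wide.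

No step beyond the scatter is therefore expected in this assay, and the estimated step is a 1.0-fold lower number from compound 2 to compound 3 (0.01 log units; within the scatter). The estimate for compound 3 is 5 nM, with an expected range of 1.5 nM to 20 nM.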

Compound 3, half-maximal inhibitory concentration: 4.8 nM
Beside the measured number, compound 3's estimate is 1.0-fold (0.02 log units) above it; measured number inside the range.
By their numbers in this assay, from the lowest: compounds 1, 3 and 2 (each within the scatter of the next).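

In this assay, the group of compound 3, which has no ring and carries 1 double bond outside aromatic rings, stands level with both earlier groups on a nitrogen on an aromatic ring (a 1.1-fold lower number from compound 2 to compound 3 (0.03 log units; within the scatter); a 1.5-fold higher number from compound 1 to compound 3 (0.17 log units; within the scatter)). The earlier compounds shown here showed this only for methyl and 1,3-thiazol-2-yl, whereas the third group also differs in its counts, with 1 hydrogen-bond donor and 1 hydrogen-bond acceptor against 0 and 2 for 1,3-thiazol-2-yl, so the read-out does not separate three unlike groups at this place. No measurement at hand accounts for this flat picture.

Open, as far as these compounds go, is whether the picture holds for a primary amine, a carboxylic acid or a longer alkyl chain on that same nitrogen. Going by these compounds alone, also open is whether replacing the nitrile or the phenyl on the shared core with another group, such as an amide in place of the nitrile, gives a step beyond the scatter, as every step so far falls on this one nitrogen and all of them stay within it.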